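Swapping bromo for butyl on the phenyl ring of compound 3

This account rests on a few compounds, and the source may have more. Where it says the series, first, only, none or still open, it means among the compounds named here.

Measured so far:
Compound 1 `CCOC(=O)c1cnc2n(c1=O)C(C)CC/C2=N\Nc1ccccc1C(=O)O`: 10 umol/kg
Compound 2 `CC1C/C(=N\Nc2ccccc2)c2ncc(C(=O)O)c(=O)n2C1`: 5.7 umol/kg
Compound 3 `CC1CC/C(=N\Nc2ccc(Br)cc2)c2ncc(C(=O)O)c(=O)n21`: 0.8 umol/kg

The three measured compounds were tested in a functional assay on the whole organism for inhibition, with Rattus norvegicus as the target; a lower number here means that less compound is needed, a higher number that more compound is needed for the effect. Compound 1 gives 10 umol/kg and compound 2 gives 5.7 umol/kg. Compound 3 stands lowest of the three with 0.8 umol/kg; its gap to compound 2 and its gap to compound 1 both lie beyond the usual scatter, so compound 3 needs the least compound of the three for the effect.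

Compound 4 `CCCCc1ccc(N/N=C2\CCC(C)n3c2ncc(C(=O)O)c3=O)cc1` has not yet been measured. It differs from compound 3 in one place: butyl in place of bromo on an aromatic carbon. Going by the values given here, no pair of measured compounds differs by a change of this kind, so no measured step guides the expectation directly. Both bromo and butyl are groups without hydrogen-bond donors or acceptors on the same aromatic carbon, and the expectation is a step of modest size in this assay, either direction, possibly none beyond the scatter, with a slight lean towards a higher number for the larger group.

For compound 4 the estimate is 1.5 umol/kg, with a range from 0.4 umol/kg to 6 umol/kg, which means an expected step of a 1.9-fold higher number from compound 3 to compound 4 (0.27 log units; within the scatter).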

Compound 4, dose for 50% inhibition: 7.8 umol/kg
For compound 4 the middle estimate is 5.2-fold (0.72 log units) below the measured one; the measured number lies above the stated range.
By their numbers in this assay, from the lowest: compound 3; then compounds 2, 4 and 1 (each within the scatter of the next).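

In this assay, replacing bromo with butyl on the aromatic carbon para to a large group gives a 9.8-fold higher number from compound 3 to compound 4 (0.99 log units; beyond the scatter), so the group at this position can clearly change the dose needed. The step comes with no change in hydrogen-bond donors, hydrogen-bond acceptors or net charge, so those counts cannot distinguish the two groups, although their effects in the assay differ. Nothing measured here accounts for the size of this step.

This single pair cannot separate the loss of bromo from the arrival of butyl. A chloro group or a methyl group on the same carbon, or a chain shorter than butyl such as ethyl, would show whether the dose rises gradually with chain length or depends on something else about these groups.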